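Compound 2 to compound 4: an aryl exchange

This account rests on a few compounds, and the source may have more. Where it says the series, first, only, none or still open, it means among the compounds named here.

Measured in a functional assay on MGC-803 cells (Homo sapiens) for antiproliferative activity, read by MTT assay, with a stated time of 72 h (on this read-out lower numbers stand for stronger inhibition and higher numbers for weaker inhibition), so far
- compound 1 `CCCSc1nc(N/N=C(\C)c2ccc(O)cc2)c2nnn(Cc3ccccc3)c2n1` gives 16700 nM
- compound 2 `CCCSc1nc(N/N=C/c2ccccc2Cl)c2nnn(Cc3ccccc3)c2n1` gives 10900 nM
- compound 3 `CCCSc1nc(N/N=C(\C)c2ccccc2O)c2nnn(Cc3ccccc3)c2n1` gives 2310 nM

Compound 2 sits at the upper end of these numbers: a 1.5-fold lower number from compound 1 to compound 2 (0.19 log units; within the scatter) shows no separation and a 4.7-fold lower number from compound 2 to compound 3 (0.67 log units; beyond the scatter) shows a clear gap. The change to compound 4 `CCCSc1nc(N/N=C/c2ccc(N(C)C)cc2)c2nnn(Cc3ccccc3)c2n1` puts 4-(dimethylamino)phenyl in place of 2-chlorophenyl. It is counted as 4-(dimethylamino)phenyl in place of 2-chlorophenyl on a carbon with a double bond to nitrogen and sits on a carbon with a double bond to nitrogen. For the measured compounds named here, no measured step makes this exchange. The closest is a 7.2-fold lower number from compound 1 to compound 3 (0.86 log units; beyond the scatter) on the same carbon. That modest step shows the number can move with this group but gives no direction here. In this assay the expected 1.2-fold lower number from compound 2 to compound 4 (0.08 log units; within the scatter) stays about within the scatter, with no firm direction. The estimated value for compound 4 is 9000 nM with an expected range from 3000 nM to 27000 nM here.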

Compound 4, half-maximal inhibitory concentration: 13100 nM
Compound 4: middle estimate off by 1.5-fold (0.16 log units), on the low side, within the range that was stated.
By their numbers in this assay, from the lowest: compound 3; then compounds 2, 4 and 1 (each within the scatter of the next).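

In this assay, a 1.2-fold higher number from compound 2 to compound 4 (0.08 log units; within the scatter) shows that 4-(dimethylamino)phenyl and 2-chlorophenyl cannot be told apart on the carbon with a double bond to nitrogen, although the entering group is larger by the count and carries a hydrogen-bond acceptor. At this place, then, a change of aryl group does not always move the number, in contrast to a 7.2-fold lower number from compound 1 to compound 3 (0.86 log units; beyond the scatter). No measurement here offers an explanation for this result.

Still open, as far as these compounds go, is whether a carboxylic acid on the phenyl ring or a pyridyl group in its place would separate from compound 2.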